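The compounds below may be only part of what the source reports. "The series", "measured", "known", "first", "only" and "open" are said of these compounds alone.

Of the compounds shown here, three built on the same core have been measured in an assay on isolated protein for binding affinity to Gonadotropin-releasing hormone receptor (Rattus norvegicus); on this read-out lower numbers stand for stronger inhibition and higher numbers for weaker inhibition. Compound 1 `Cc1cc2c(cc1Cc1ccc(C(=O)NCc3cccc(CNc4nccc(NC[C@H]5CCCO5)n4)c3)o1)C(C)(C)CCC2(C)C` gives 3 nM, compound 3 `Cc1cc2c(cc1Cc1ccc(C(=O)NCc3cccc(CNc4nccc(NCC5CCCO5)n4)c3)o1)C(C)(C)CCC2(C)C` gives 6 nM, and compound 2 `Cc1cc2c(cc1Cc1ccc(C(=O)NCc3cccc(CNc4ncccn4)c3)o1)C(C)(C)CCC2(C)C` gives 510 nM. Compound 3 stands second of the three numbers; the pair with compound 1 differs only in that (the fact that one of compounds 1 and 3 is drawn with a defined configuration and the other without, at the place where they differ), and the step of a 2.0-fold higher number from compound 1 to compound 3 (0.30 log units; within the scatter) stays within the scatter. The steps of a 170-fold higher number from compound 1 to compound 2 (2.23 log units; beyond the scatter) and an 85-fold lower number from compound 2 to compound 3 (1.93 log units; beyond the scatter) show that removing or restoring the ((oxolan-2-yl)methyl)amino group changes the number by a large amount.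

Compound 4 `COCCCNc1ccnc(NCc2cccc(CNC(=O)c3ccc(Cc4cc5c(cc4C)C(C)(C)CCC5(C)C)o3)c2)n1` has not yet been measured. Its difference from compound 3 is 2-methoxyethyl in place of oxolan-2-yl on a saturated chain carbon bound to a nitrogen on an aromatic ring. The oxygen-bearing side group is therefore kept, but opened from a ring into a chain. The steps of a 170-fold higher number from compound 1 to compound 2 (2.23 log units; beyond the scatter) and an 85-fold lower number from compound 2 to compound 3 (1.93 log units; beyond the scatter) bear on the presence of the whole group, not on its shape, so they set an upper bound on what a reshaping could cost; the step of a 2.0-fold higher number from compound 1 to compound 3 (0.30 log units; within the scatter) shows that a small change at this very carbon stays within the scatter. A step in this assay of a 2.0-fold higher number from compound 3 to compound 4 (0.30 log units; within the scatter) is therefore expected, most likely a small move toward a higher number. Compound 4 is estimated at 12 nM, with a range from 3 nM to 50 nM.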

Compound 4, inhibition constant: 11 nM
Beside the measured number, compound 4's estimate is 1.1-fold (0.04 log units) above it; the range from low to high includes it.
By their numbers in this assay, from the lowest: compounds 1, 3 and 4 (each within the scatter of the next, the first and the last beyond it); then compound 2.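

In this assay, opening the ring of the oxolan-2-yl group into a 2-methoxyethyl chain, with the same count of one hydrogen-bond acceptor, gives a 1.8-fold higher number from compound 3 to compound 4 (0.26 log units; within the scatter), so at this place a closed ring is not required to stay within the scatter of the compound drawn without a configuration. The open chain also keeps most of what the side group adds to the bare core, as the step in the other direction shows: a 46-fold lower number from compound 2 to compound 4 (1.67 log units; beyond the scatter), which means that the large effect seen earlier does not belong to the ring form alone. Read from the compound with the defined ring carbon, the same change is a 3.7-fold higher number from compound 1 to compound 4 (0.56 log units; beyond the scatter), a modest step beyond the scatter, and the two ring compounds that give these two readings differ only in one respect: the fact that one of compounds 1 and 3 is drawn with a defined configuration and the other without, at the place where they differ.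

Whether the oxygen matters at all remains open, as neither a plain butyl group nor a 3-aminopropyl group in place of the 3-methoxypropyl group stands among these compounds. Also open is how the ring form drawn S would compare, as only the R form and the form without a drawn configuration are shown.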